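A chloro group added to compound 2

A few compounds are considered here, and "the series" means these few. Any claim that something is new, unique, unknown or untested is made for them only; others in the source may bear on it.

Among the compounds with values here, in a functional assay on Hep 3B2 cells (Homo sapiens) for cytotoxicity, read by MTT assay (a higher number here means a weaker inhibitor, a lower number a stronger inhibitor), compound 2 `CC(=O)N1CCC(C[C@@H](c2nc3ccccc3n2C)N2C(=O)CN(c3ccc(Oc4ccccc4)cc3)C2=O)CC1` gives 32100 nM, the only true number available so far. Compound 1 `Cc1ccc2nc([C@H](CC3CCN(C(=O)C(C)C)CC3)N3C(=O)CN(c4ccc(Oc5ccccc5)cc4)C3=O)n(C)c2c1` stands at > 100000 nM, which is a limit of the assay and not a number. Compound 3 `CC(=O)N1CCC(C[C@@H](c2nc3ccc(Cl)cc3n2C)N2C(=O)CN(c3ccc(Oc4ccccc4)cc3)C2=O)CC1` departs from compound 2 by a single change, chloro in place of hydrogen on an aromatic carbon. Within the data shown here, no measured step bears on this change. The expected step in this assay is modest, a 1.5-fold lower number from compound 2 to compound 3 (0.16 log units; within the scatter), toward a stronger inhibitor, and it may not exceed the scatter. Compound 3 is estimated at 22000 nM, within an expected range of 7000 nM to 70000 nM.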

Compound 3, half-maximal inhibitory concentration: > 100000 nM
Compound 3 gave a limit, no number (the forecaster's own chance of this, stated with the estimate: 12%); middle value at least 4.5-fold (0.65 log units) away from the limit.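

In this assay, the change to 6-chloro-1-methyl-1H-benzimidazol-2-yl gives an at least 3.1-fold higher number from compound 2 to compound 3 (0.49 log units; beyond the scatter), the first sign that this aromatic carbon responds to substitution, here toward a weaker inhibitor. As far as these compounds go, compound 3 gives > 100000 nM, which is a limit of the assay and not a number, so the true size of the step stays unknown. The step is a lower bound, set by the ceiling of the assay: the limit of > 100000 nM in this assay, at which 2 of the 3 values shown sit.

The compounds shown leave open whether fluoro or methoxy on the same aromatic carbon would move the number in the same direction.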